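Swapping the aryl ether in a triazine antiproliferative series

The source may report more compounds than this note shows. Statements on the series, on what has been measured and on what is new or still open speak of the compounds shown alone.

Compound 2 `NC1=NC2(CCOCC2)N(OCCCOc2ccccc2Cl)C(N)=N1` gives 1430 nM in a functional assay on MDA-MB-231 cells (Homo sapiens) for antiproliferative activity, read by MTT assay, with a stated time of 72 h (a lower number here means a stronger inhibitor, a higher number a weaker inhibitor), the higher of the two numbers; compound 1 `NC1=NC2(CCOCC2)N(OCCCOc2cccc(Cl)c2Cl)C(N)=N1` gives 140 nM, and a 10-fold higher number from compound 1 to compound 2 (1.01 log units; beyond the scatter). Compound 3 `Cc1cc(C)cc(OCCCON2C(N)=NC(N)=NC23CCOCC3)c1` differs from compound 2 by 3,5-dimethylphenyl in place of 2-chlorophenyl on an oxygen on a saturated carbon. No measured step covers this change: the only step shown concerns a chloro on the aromatic ring, not a change of the aryl group itself, so it gives no direct guide. Compound 3 is therefore expected to stay near compound 2, with a 1.2-fold lower number from compound 2 to compound 3 (0.08 log units; within the scatter) and an estimate of 1200 nM between 250 nM and 6000 nM.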

Compound 3, half-maximal inhibitory concentration: 3570 nM
Estimate against measurement, compound 3: 3.0-fold (0.47 log units) below; measured number inside the range.
By their numbers in this assay, from the lowest: compound 1; then compound 2; then compound 3.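

Exchanging the whole aryl group on this oxygen, rather than one chloro on it, also moves the number in this assay beyond the scatter (a 2.5-fold higher number from compound 2 to compound 3 (0.40 log units; beyond the scatter)). Against the dichlorinated aryl group, the same 3,5-dimethylphenyl costs far more (a 26-fold higher number from compound 1 to compound 3 (1.41 log units; beyond the scatter)), making compound 3 the weakest of the three. Nothing given here accounts for this order.

As far as these compounds go, because 3,5-dimethylphenyl differs from both chlorinated groups in several ring substituents at once, the contribution of each stays open. Unsubstituted phenyl, a pyridine ring or a longer chain at this place remain untested in the compounds shown.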